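Series notes: chloro steps in a cytotoxicity read-out

A few compounds are considered here, and "the series" means these few. Any claim that something is new, unique, unknown or untested is made for them only; others in the source may bear on it.

Measured compounds in a functional assay on Raji cells (Homo sapiens) for cytotoxicity, with a stated time of 72 h; on this read-out lower numbers stand for an effect already at smaller amounts and higher numbers for an effect only at larger amounts of compound:
compound 1 `CC(C)=CCC[C@@](C)(/C=C/c1ccccc1)/C=C/c1ccc(O)cc1` — a limit of the assay, > 26000 nM.
compound 2 `CC(C)=CCC[C@](C)(/C=C/c1ccc(O)cc1)/C=C/c1cccc(Cl)c1` — a limit of the assay, > 26000 nM.
compound 3 `C=C[C@@](C)(/C=C/c1ccc(Nc2ccc(Cl)cc2)cc1)CCC=C(C)C` — a limit of the assay, > 26000 nM.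

The change chloro in place of hydrogen on an aromatic carbon gives a step that the two limits leave unreadable from compound 1 to compound 2; both values sit at the limit of > 26000 nM in this assay, at which 3 of the 3 values shown sit. How the core of compound 3 differs from that of compound 1 is not broken down here. Compound 4 `C=C[C@@](C)(/C=C/c1ccc(Nc2ccc(Cl)c(Cl)c2)cc1)CCC=C(C)C` carries the change (chloro in place of hydrogen on an aromatic carbon), the same kind of change as from compound 1 to compound 2, but here the place is also ortho to a chloro group. With all three measured values at the limit, the step from compound 3 to compound 4 in this assay is expected to be a step that the limit leaves unreadable from compound 3 to compound 4, most likely again unreadable. Compound 4 is therefore estimated at 30000 nM, with a high chance that only a limit is reported.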

Compound 4, half-maximal effective concentration: > 26000 nM
Compound 4 ended at the assay's limit; the forecaster's own chance of this, stated with the estimate: 80%; the middle value is on the limit's open side.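

Compound 3 and compound 4 both sit at a limit of the assay, so no new step can be read between them: the limit of > 26000 nM in this assay, at which 4 of the 4 values shown sit.
The compounds shown leave open how large any chloro step is and at what concentration any of them takes effect.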